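Amide aryl variation on the fluorophenyl chromone series

This account rests on a few compounds, and the source may have more. Where it says the series, first, only, none or still open, it means among the compounds named here.

Two amides on the shared core have been measured. Compound 1 `O=C(Nc1cccc(-c2oc3cc(-c4ccc(F)cc4)ccc3c(=O)c2O)c1)c1ccc(C(F)(F)F)cc1` gives 33000 nM in a functional assay on GTL 16 cells for antiproliferative activity against GTL 16 cell line (Homo sapiens), read by CCK-8 assay, with a stated time of 72 h; a lower number here means a stronger inhibitor, a higher number a weaker inhibitor. Compound 2 `Cc1cccc(C(=O)Nc2cccc(-c3oc4cc(-c5ccc(F)cc5)ccc4c(=O)c3O)c2)c1` gives 10900 nM in this assay. Among the measured compounds shown here, the only step between them, a 3.0-fold lower number from compound 1 to compound 2 (0.48 log units; beyond the scatter), places compound 2 at the lowest of the two numbers so far, with compound 1 the nearest and the only other point.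

Compound 3 `N#Cc1ccc(C(=O)Nc2cccc(-c3oc4cc(-c5ccc(F)cc5)ccc4c(=O)c3O)c2)cc1` is not yet measured. It differs from compound 2 by 4-cyanophenyl in place of 3-methylphenyl on a carbonyl carbon. For the measured compounds named here, the step of a 3.0-fold lower number from compound 1 to compound 2 (0.48 log units; beyond the scatter) is the one measured change at this carbonyl carbon and bears directly on it, though neither of the two measured groups is the one entering here. On that basis compound 3 is expected to return part of the way toward compound 1, an expected step of a 1.8-fold higher number from compound 2 to compound 3 (0.26 log units; within the scatter). In this assay compound 3 is estimated at 20000 nM, with an expected range from 7000 nM to 60000 nM.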

Compound 3, half-maximal inhibitory concentration: 31800 nM
Estimate against measurement, compound 3: 1.6-fold (0.20 log units) below; the range from low to high includes it.
By their numbers in this assay, from the lowest: compound 2; then compounds 3 and 1 (each within the scatter of the next).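

In this assay, 4-cyanophenyl in place of 3-methylphenyl on the carbonyl carbon gives a 2.9-fold higher number from compound 2 to compound 3 (0.47 log units; beyond the scatter), about the same size as a 3.0-fold lower number from compound 1 to compound 2 (0.48 log units; beyond the scatter) in the opposite direction. Cyano in place of trifluoromethyl gives a 1.0-fold lower number from compound 1 to compound 3 (0.02 log units; within the scatter), so these two groups cannot be told apart here, and among the three compounds only the 3-methylphenyl amide, compound 2, stands beyond the scatter from both others. Nothing available accounts for this difference.

The step from compound 2 to compound 3 changes both the substituent and the name's ring number, so these compounds do not separate the two changes. Also open, going by these compounds, is how the series responds to an aromatic ring carrying an amine or a carboxylic acid, or to cyclohexyl in place of the aromatic ring.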